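Working notes: 4-bromophenyl to 2,4-difluorophenyl

The source may hold more compounds than are shown below. What is called first, only, known or untested is meant among the compounds shown, and "the series" means these compounds.

Measured in a functional assay on MCF7 cells (Homo sapiens) for cytotoxicity, read by MTT assay, with a stated time of 48 h; on this read-out higher numbers stand for weaker inhibition and lower numbers for stronger inhibition:
- Compound 1 `COc1ccc(-c2c[nH]c(=O)n2-c2cc(OC)c(OC)c(OC)c2)cc1N`: > 50000 nM (a limit)
- Compound 2 `COc1ccc(-c2cn(C(=O)Nc3cc(OC)c(OC)c(OC)c3)c(=O)n2-c2cc(OC)c(OC)c(OC)c2)cc1`: > 50000 nM (a limit)
- Compound 3 `COc1cc(-n2c(-c3ccc(Br)cc3)cn(C(C)=O)c2=O)cc(OC)c1OC`: 10600 nM

Within the data shown here, compound 3 gives the only actual number in this set, 10600 nM. Compound 1 reads > 50000 nM, which is a limit and not a number. Compound 2 reads > 50000 nM, also a limit and not a number.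

The next compound is compound 4 `COc1cc(-n2c(-c3ccc(F)cc3F)cn(C(C)=O)c2=O)cc(OC)c1OC`, with 2,4-difluorophenyl in place of 4-bromophenyl on an aromatic carbon. The acetyl group stays as it is in compound 3.

Among the measured compounds shown here, no measured pair in the set sizes such an exchange, so the estimate rests on compound 3 alone, at 10600 nM. In this assay a small step toward weaker inhibition is expected, quite possibly none beyond the scatter. The expected step is a 1.3-fold higher number from compound 3 to compound 4 (0.12 log units; within the scatter). Compound 4 is expected at 14000 nM, with an estimated range of 4500 nM to 40000 nM.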

Compound 4, half-maximal inhibitory concentration: 49300 nM
Compound 4: middle estimate off by 3.5-fold (0.55 log units), on the low side, outside the stated range (above it).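

In this assay, 2,4-difluorophenyl in place of 4-bromophenyl gives a 4.7-fold higher number from compound 3 to compound 4 (0.67 log units; beyond the scatter), so with the acetyl group kept, the aryl group on this aromatic carbon is not an indifferent position. This is the only step shown between compounds that differ in one place, and it runs toward weaker inhibition, leaving the 4-bromophenyl of compound 3 as the better of the two groups. Compound 4 also leaves little room on this read-out before the limit that other compounds in the set reach: the limit of > 50000 nM in this assay, at which 2 of the 4 values shown sit.

The compounds shown do not separate the departure of the bromine from the arrival of the two fluorines, and a 4-fluorophenyl or 4-chlorophenyl group at this position, with the acetyl group kept, would bear on that. Also open, going by these compounds, is whether either aryl group keeps its rank when a propionyl group replaces the acetyl group.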